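From Ethyl to Benzoyl on a Saturated Ring Carbon

A few compounds are considered here, and "the series" means these few. Any claim that something is new, unique, unknown or untested is made for them only; others in the source may bear on it.

Within the data shown here, in a functional assay for inhibition, with Homo sapiens as the target (a lower number here means a stronger inhibitor, a higher number a weaker inhibitor), only two compounds have numbers so far: compound 1 (`Cc1cc2c(cc1C(=O)N=C(N)N)S(=O)(=O)C(C)(C)CC2C`) gives 1100 nM and compound 2 (`CCC1(O)CS(=O)(=O)c2cc(C(=O)N=C(N)N)c(C)cc21`) gives 77 nM in the same test. Compound 2 therefore holds the lower of the two numbers, which marks it as the stronger inhibitor, and the gap between the two lies beyond the usual scatter of repeat measurements.

The next compound is compound 3 (`Cc1cc2c(cc1C(=O)N=C(N)N)S(=O)(=O)CC2(O)C(=O)c1ccccc1`). Compared with compound 2, it carries benzoyl in place of ethyl on a saturated ring carbon, two ring bonds from the ring sulfur (benzoyl in place of ethyl on a saturated ring carbon). Among the measured compounds shown here, no measured pair differs at this place alone, so the data offer no direct guide to this change, and any forecast is uncertain.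

The expectation starts from compound 2 at 77 nM as the reference point. The estimated change is a 2.3-fold higher number from compound 2 to compound 3 (0.37 log units; beyond the scatter) and points toward weaker inhibition, a modest step only just beyond the scatter. In this assay compound 3 is expected at 180 nM with a range of 40 nM to 800 nM around that estimate.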

Compound 3, half-maximal inhibitory concentration: 157 nM
Compound 3: middle estimate off by 1.1-fold (0.06 log units), on the high side; measured number inside the range.
By their numbers in this assay, from the lowest: compound 2; then compound 3; then compound 1.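

Among these compounds, this is the first measured change at this saturated ring carbon, and in this assay it gives a 2.0-fold higher number from compound 2 to compound 3 (0.31 log units; beyond the scatter), a modest step. Ethyl, with 2 heavy atoms, gives way to benzoyl, with 8 heavy atoms and a six-membered aromatic ring, yet compound 3 still gives 157 nM, so this much larger group costs only a modest step in inhibition. Nothing measured here explains why the number rises.

Benzoyl brings in an aromatic ring, a carbonyl and a hydrogen-bond acceptor all at once, so this single step cannot show which part accounts for the difference, and a plain phenyl or a longer chain such as propyl on the same carbon would help to separate them. Going by these compounds, whether an amine or a carboxylic acid at this carbon would give a lower or a higher number than ethyl also remains open, as does whether a step of this size would hold in any other test.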